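A Methoxy in Place of Ethyl at the Aryl Ether

This account rests on a few compounds, and the source may have more. Where it says the series, first, only, none or still open, it means among the compounds named here.

Measured compounds:
Compound 1, `CCCOc1ccccc1C1CC(=O)c2ccccc2O1`, in a functional assay on J774.A1 cells (Mus musculus) for inhibition, read by Griess assay, with stated times of 1 h and 24 h (a higher number here means a weaker inhibitor, a lower number a stronger inhibitor), compound 1 gives 44600 nM.
Compound 2, `CCCCOc1ccccc1C1CC(=O)c2ccccc2O1`, gives 47700 nM.
Compound 3, `O=C1CC(c2ccccc2OCc2cccc(F)c2)Oc2ccccc21`, gives 13200 nM.

Compound 1 stands second highest of the three numbers. Its step to compound 2, a 1.1-fold higher number from compound 1 to compound 2 (0.03 log units; within the scatter), lies within the scatter, while a 3.4-fold lower number from compound 1 to compound 3 (0.53 log units; beyond the scatter) is a modest lowering, as is a 3.6-fold lower number from compound 2 to compound 3 (0.56 log units; beyond the scatter).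

Compound 4, `COCOc1ccccc1C1CC(=O)c2ccccc2O1`, differs from compound 1 by methoxy in place of ethyl on a saturated chain carbon bound to an oxygen on an aromatic ring; read one bond further out, propoxy becomes methoxymethoxy. Going by the values given here, no measured step replaces a chain carbon with an oxygen. Among the compounds with values here, the only step that keeps an alkyl chain, from compound 1 to compound 2, barely moves the number, and the modest lowering seen in a 3.4-fold lower number from compound 1 to compound 3 (0.53 log units; beyond the scatter) belongs to a 3-fluorophenyl, not to a methoxy. The expected step is therefore a 1.0-fold higher number from compound 1 to compound 4 (0.00 log units; within the scatter), none beyond the scatter. Compound 4 is estimated at 45000 nM, with a range from 20000 nM to 100000 nM.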

Compound 4, half-maximal inhibitory concentration: 35200 nM
Compound 4: the middle estimate sits 1.3-fold (0.11 log units) above what was measured, within the range that was stated.
By their numbers in this assay, from the lowest: compound 3; then compounds 4, 1 and 2 (each within the scatter of the next).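

In this assay the change from an all-carbon chain to one carrying an oxygen, methoxy in place of ethyl, leaves the number within the scatter (a 1.3-fold lower number from compound 1 to compound 4 (0.10 log units; within the scatter)), and the same holds against the longer chain (a 1.4-fold lower number from compound 2 to compound 4 (0.13 log units; within the scatter)). Compound 3 stays apart from this group, since methoxy in place of 3-fluorophenyl gives a modest rise beyond the scatter (a 2.7-fold higher number from compound 3 to compound 4 (0.43 log units; beyond the scatter)). No evidence on the reason for these numbers is at hand.

On these data alone, whether an amine or a carboxylic acid in place of the ethyl would move the number stays open. So does whether a phenyl without the fluorine would match compound 3.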